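Swapping a Difluorobenzyl Group for Methoxy on the Piperidine

A few compounds are considered here, and "the series" means these few. Any claim that something is new, unique, unknown or untested is made for them only; others in the source may bear on it.

Compound 1 `CC(C(=O)NCc1ccc(C(F)(F)F)nc1NC1CCCCC1)c1ccc(NS(C)(=O)=O)c(F)c1` gives 20.4 nM in a functional assay on CHO-K1 cells for antagonist activity at transient receptor potential cation channel subfamily V member 1 (Homo sapiens), read by FLIPR; on this read-out higher numbers stand for weaker inhibition and lower numbers for stronger inhibition.
Compound 2 `CC(C(=O)NCc1ccc(C(F)(F)F)nc1N1CCCCC1C)c1ccc(NS(C)(=O)=O)c(F)c1` gives 2.9 nM in this assay.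
Compound 3 `CC(C(=O)NCc1ccc(C(F)(F)F)nc1N1CCC(Cc2cc(F)cc(F)c2)CC1)c1ccc(NS(C)(=O)=O)c(F)c1` gives 0.4 nM in this assay.

Compound 3 stands lowest of the three, well apart from compound 2 and from compound 1. Compound 4 `COC1CCN(c2nc(C(F)(F)F)ccc2CNC(=O)C(C)c2ccc(NS(C)(=O)=O)c(F)c2)CC1` differs from it by methoxy in place of 3,5-difluorobenzyl on a saturated ring carbon. No measured step matches this exchange; the only listed step, a 7.0-fold lower number from compound 1 to compound 2 (0.85 log units; beyond the scatter), concerns a different position. The values of compound 2 and compound 3 show that a larger group on the saturated ring went with a lower number, and compound 4 carries a small group again, so a moderate rise, a 6.3-fold higher number from compound 3 to compound 4 (0.80 log units; beyond the scatter), is expected. Compound 4 is therefore estimated at 2.5 nM, likely between 0.8 nM and 8 nM.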

Compound 4, inhibition constant: 2.4 nM
Estimate against measurement, compound 4: 1.0-fold (0.02 log units) above, within the range that was stated.
By their numbers in this assay, from the lowest: compound 3; then compounds 4 and 2 (each within the scatter of the next); then compound 1.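

At the saturated ring carbon, three ring bonds from the ring nitrogen, methoxy does not match 3,5-difluorobenzyl in this assay (a 6.0-fold higher number from compound 3 to compound 4 (0.78 log units; beyond the scatter)). Even so, 4-methoxypiperidin-1-yl cannot be told apart from 2-methylpiperidin-1-yl (a 1.2-fold lower number from compound 2 to compound 4 (0.08 log units; within the scatter)), and it still improves on cyclohexylamino (an 8.5-fold lower number from compound 1 to compound 4 (0.93 log units; beyond the scatter)). No measurement here explains these differences. The compounds shown leave open whether the aromatic ring or the fluorine atoms of 3,5-difluorobenzyl matter more. A plain benzyl group or an amine on that ring carbon would bear on this question.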